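This account rests on a few compounds, and the source may have more. Where it says the series, first, only, none or still open, it means among the compounds named here.

Series notes on cytotoxicity. In an ADME assay on MDCK cells (Canis lupus familiaris) for cytotoxicity (on this read-out lower numbers stand for higher toxicity in this test and higher numbers for lower toxicity in this test), compound 1 `Cc1ncc(Sc2nccn2C)c(-c2ccccc2O)n1` gives 577000 ug/mL. Compound 2 `COc1ccc(O)c(-c2ncncc2Sc2nccn2C)c1` gives 618000 ug/mL in this assay, a number within the scatter of that of compound 1. Compound 3 `Cn1ccnc1Sc1cnc(C(C)(C)C)nc1-c1cc(Cl)ccc1O` gives 111000 ug/mL in this assay, which lies beyond the scatter below compound 1. Among the three numbers compound 1 therefore stands second highest, indistinguishable from compound 2 and clearly set apart from compound 3.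

Compound 4 `Cn1ccnc1Sc1cnc(-c2ccc(Cl)cc2)nc1-c1ccccc1O` is not yet measured. It differs from compound 1 in one place: 4-chlorophenyl in place of methyl on an aromatic carbon. Within the data shown here, no measured pair differs in exactly this way, so the size of the step must be estimated from the three numbers alone. Compound 3, the measured compound that departs furthest from compound 1, gives the lowest number, and a downward step of similar order is expected here: the estimated step is a 2.9-fold lower number from compound 1 to compound 4 (0.46 log units; beyond the scatter). For compound 4 the expected value in this assay is 200000 ug/mL, with a range from 70000 ug/mL to 500000 ug/mL.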

Compound 4, half-maximal cytotoxic concentration: 80100 ug/mL
Estimate against measurement, compound 4: 2.5-fold (0.40 log units) above; the range from low to high includes it.
By their numbers in this assay, from the lowest: compounds 4 and 3 (each within the scatter of the next); then compounds 1 and 2 (each within the scatter of the next).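

Among these compounds, this is the first single-place change that can be read, and it shows that the carbon between two ring nitrogen atoms is not indifferent to what it carries. Read in this assay the replacement of methyl by 4-chlorophenyl gives a step beyond the scatter (a 7.2-fold lower number from compound 1 to compound 4 (0.86 log units; beyond the scatter)), so the read-out responds at this position to a change that brings in a six-membered aromatic ring of carbon only and a chlorine, with no hydrogen-bond donors or acceptors entering or leaving. No measurement at hand bears on the origin of this step.

Going by these compounds, whether the step goes with the chlorine or with the phenyl ring itself remains open. A plain phenyl, a morpholine or a carboxylic acid on this carbon would help to separate these readings and show how far the step extends.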